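Trading Cycloheptyl for 2,5-Dichlorophenyl on the Ring Nitrogen

A few compounds are considered here, and "the series" means these few. Any claim that something is new, unique, unknown or untested is made for them only; others in the source may bear on it.

Measured so far, in a functional assay on CHO cells with adenosine receptor A1 (Homo sapiens) as the target, read by cAMP accumulation and immunoassay, with a stated time of 6 min, tested at 1 uM; a higher number here means a weaker effect of the compound at the concentration tested, a lower number a stronger effect:
compound 1, `Nc1scc(CN2CCN(c3ccc(F)cc3Cl)CC2)c1C(=O)c1ccc(Cl)cc1`, gives -39%
compound 2, `Nc1scc(CN2CCN(c3ccc(Cl)c(C(F)(F)F)c3)CC2)c1C(=O)c1ccc(Cl)cc1`, gives -47%
compound 3, `Nc1scc(CN2CCN(C3CCCCCC3)CC2)c1C(=O)c1ccc(Cl)cc1`, gives 3.7%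

Compound 3 stands highest of the three numbers, so it shows the weakest effect; its nearest neighbour is compound 1 and its furthest is compound 2, both beyond the scatter. Compound 4, `Nc1scc(CN2CCN(c3cc(Cl)ccc3Cl)CC2)c1C(=O)c1ccc(Cl)cc1`, differs from compound 3 in one place: 2,5-dichlorophenyl in place of cycloheptyl on an amine nitrogen in a ring.

For the measured compounds named here, two measured steps bear on this change, each swapping a group on the same ring nitrogen. Going from an aromatic ring to cycloheptyl gave a number 42.7 percentage points higher from compound 1 to compound 3 (beyond the scatter) and a number 50.7 percentage points higher from compound 2 to compound 3 (beyond the scatter), both large. The pair of compound 1 and compound 2 shows a number 8 percentage points lower from compound 1 to compound 2 (within the scatter), so the two aromatic rings tried so far give similar numbers. Compound 4 returns an aromatic ring to that position, so a large step downward in this assay is expected, a number 45.7 percentage points lower from compound 3 to compound 4 (beyond the scatter). Compound 4 is therefore estimated at -42%, with a range from -60% to -20%.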

Compound 4, a percentage reported as activity, at one concentration (the size of the read-out at that concentration, not a potency): -42%
Compound 4: middle estimate and measured number agree at the digits printed, and the stated range covers the measured number.
By their numbers in this assay, from the lowest: compounds 2, 4 and 1 (each within the scatter of the next); then compound 3.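

In this assay a third aromatic ring on the amine nitrogen again stands well apart from cycloheptyl (a number 45.7 percentage points lower from compound 3 to compound 4 (beyond the scatter)), so this gap now rests on three different aromatic rings rather than two. The substituents on those rings make no readable difference among these compounds: 2,5-dichlorophenyl stays within the scatter of 4-chloro-3-(trifluoromethyl)phenyl (a number 5 percentage points higher from compound 2 to compound 4 (within the scatter)) and of 2-chloro-4-fluorophenyl (a number 3 percentage points lower from compound 1 to compound 4 (within the scatter)). Nothing available explains why the aromatic rings and cycloheptyl give such different numbers.

Every aromatic ring shown carries chlorine, so it remains open whether a plain phenyl, a pyridine ring or a benzyl group would give numbers like those of compounds 1, 2 and 4. Going by these compounds, it also remains open whether a cyclohexyl ring would fall with cycloheptyl.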